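This account rests on a few compounds, and the source may have more. Where it says the series, first, only, none or still open, it means among the compounds named here.

Compound 1 `Fc1cccc(Cn2nnc3c(Br)cccc32)c1`: 1.6 mL/min/g
Compound 2 `Fc1ccc(Cn2nnc3c(Br)cccc32)cc1`: 1 mL/min/g
Compound 3 `Clc1ccc(Cn2nnc3c(Br)cccc32)cc1`: 2.2 mL/min/g

In an ADME assay on microsomes from liver (Rattus norvegicus, strain Wistar) for metabolic stability, tested at 2.5 uM (on this read-out higher numbers stand for fast clearance and lower numbers for slow clearance), compound 3 gives 2.2 mL/min/g, the highest of the three numbers, though its gap to compound 1 lies within the scatter. For the measured compounds named here, the one measured step that bears on this series is the halogen swap, a 2.2-fold higher number from compound 2 to compound 3 (0.34 log units; beyond the scatter), a modest but real shift. Compound 4 `Fc1cc(Cn2nnc3c(Br)cccc32)ccc1Cl` differs from compound 3 by fluoro in place of hydrogen on an aromatic carbon. Going by the values given here, no measured step adds a fluoro to a ring that already carries a chloro, so the direction of the change cannot be read from the data. The author therefore expects a step within the scatter, no change at the digits printed from compound 3 to compound 4 (within the scatter). Compound 4 is estimated at 2.2 mL/min/g, with a range from 1.2 mL/min/g to 4 mL/min/g.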

Compound 4, intrinsic clearance in a liver preparation (reported as CLH), per the amount of preparation that the assay uses: 3.1 mL/min/g
For compound 4 the middle estimate is 1.4-fold (0.15 log units) below the measured one; low and high end bracket the measured number.
By their numbers in this assay, from the lowest: compounds 2, 1, 3 and 4 (each within the scatter of the next, the first and the last beyond it).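

In this assay fluoro in place of hydrogen on an aromatic carbon, ortho to a chloro group, gives a 1.4-fold higher number from compound 3 to compound 4 (0.15 log units; within the scatter) and so stays inside the scatter. Read from the other side, chloro in place of hydrogen on the same ring gives a 1.9-fold higher number from compound 1 to compound 4 (0.29 log units; within the scatter) and so also shows no step beyond the scatter. Nothing in the data explains either step.

Going by these compounds, whether a methoxy, a trifluoromethyl or an amine at this position would stay as close remains open. So does whether the same small steps would hold with a group other than the bromo on the core.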